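The source may report more compounds than this note shows. Statements on the series, on what has been measured and on what is new or still open speak of the compounds shown alone.

In a functional assay for inhibition (on this read-out higher numbers stand for weaker inhibition and lower numbers for stronger inhibition), compound 1 (`O=S(=O)(Nc1cc(F)c(O)c(F)c1)c1ccc(N2CCCC2)cc1`) gives 97100 nM and compound 2 (`Nc1ccc(S(=O)(=O)N(Cc2ccc(Br)cc2F)c2cc(F)c(O)c(F)c2)cc1`) gives 73100 nM. Among the measured compounds shown here, these two values lie within the scatter of each other, so compound 1 stands level with the only other measured compound. Compound 3 (`COc1ccc(S(=O)(=O)Nc2cc(F)c(O)c(F)c2)cc1`), not yet measured, has methoxy in place of pyrrolidin-1-yl on an aromatic carbon. For the measured compounds named here, no measured step bears on this change, so the expected 1.8-fold lower number from compound 1 to compound 3 (0.25 log units; within the scatter) is small, towards stronger inhibition, and not beyond the scatter. For compound 3 the estimated value is 55000 nM, with an expected range of 15000 nM to 150000 nM.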

Compound 3, half-maximal inhibitory concentration: 55100 nM
Estimate against measurement, compound 3: 1.0-fold (0.00 log units) below, within the range that was stated.
By their numbers in this assay, from the lowest: compounds 3, 2 and 1 (each within the scatter of the next).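

In this assay, among the compounds shown here, the change at this aromatic carbon, para to a large group, gives a 1.8-fold lower number from compound 1 to compound 3 (0.25 log units; within the scatter) and so provides the first step that can be read at this position. Methoxy, with its 2 heavy atoms and no ring, is therefore not told apart from pyrrolidin-1-yl, with its 5 heavy atoms and five-membered ring. Nothing available offers an explanation for this result. The compounds shown leave open whether a carboxylic acid, a nitrile or a longer alkoxy chain at this carbon would give a step beyond the scatter.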